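The source may report more compounds than this note shows. Statements on the series, on what has been measured and on what is new or still open speak of the compounds shown alone.

Measured in an ADME assay on HOS cells (Homo sapiens) for cytotoxicity; on this read-out higher numbers stand for lower toxicity in this test and lower numbers for higher toxicity in this test:
- Compound 1 `CN(Cc1nc2ccccc2n1CCCCN)C1CCCc2cccnc21`: 2900 nM
- Compound 2 `CN(Cc1nc2cccc(C(=O)NCCCCN)c2[nH]1)C1CCCc2cccnc21`: > 20000 nM
- Compound 3 `CN(Cc1nc2cccc(CNCCN)c2[nH]1)C1CCCc2cccnc21`: > 20000 nM

Compound 3 stands at > 20000 nM, which is a limit of the assay and not a number. Compound 2 gives > 20000 nM, which is the same limit. Together they make up (the limit of > 20000 nM in this assay, at which 2 of the 3 values shown sit). Only compound 1 gives a true number.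

Compound 4 `CN(Cc1nc2cccc(CCCN3CCCCC3)c2[nH]1)C1CCCc2cccnc21` differs from compound 3 by one change: 2-(piperidin-1-yl)ethyl in place of (2-aminoethyl)amino on a saturated chain carbon bound to an aromatic carbon. In words, 2-(piperidin-1-yl)ethyl stands in place of (2-aminoethyl)amino on a saturated chain carbon bound to an aromatic carbon.

Going by the values given here, the only measured step is a step that the two limits leave unreadable from compound 2 to compound 3, so it offers no size to carry over. Compound 1, at 2900 nM, shows that a compound in this small set can give a readable number in this assay. A moderate move toward lower numbers, meaning higher toxicity in this test, is therefore expected, though compound 4 could also stay at the limit. The expected step is an at least 1.8-fold lower number from compound 3 to compound 4 (0.25 log units; that floor lies within the scatter). For compound 4 the estimated value is 11000 nM, with an expected range from 4000 nM to 25000 nM.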

Compound 4, half-maximal cytotoxic concentration: 8700 nM
The estimate for compound 4 lay 1.3-fold (0.10 log units) above the measured number, within the range that was stated.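

In this assay, the group on a saturated chain carbon bound to an aromatic carbon can move the read-out into a measurable range: 2-(piperidin-1-yl)ethyl in place of (2-aminoethyl)amino gives an at least 2.2-fold lower number from compound 3 to compound 4 (0.36 log units; beyond the scatter). Measured against the amide side chain of compound 2, the picture is similar, with an at least 2.2-fold lower number from compound 2 to compound 4 (0.36 log units; beyond the scatter), so this side chain brings higher toxicity in this test than either of the other two. Both steps give only a minimum size, not a true one, because compound 2 and compound 3 each sit at a limit of the assay: the limit of > 20000 nM in this assay, at which 2 of the 4 values shown sit.

The change brings in the piperidine ring and removes (2-aminoethyl)amino in one move, so the compounds shown cannot separate those two parts. As far as these compounds go, how a dimethylamino or morpholine group at the end of the same chain would read remains open.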